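Swapping 4-methoxybenzyl for hydrogen on compound 1

The source may report more compounds than this note shows. Statements on the series, on what has been measured and on what is new or still open speak of the compounds shown alone.

In a functional assay on HL-60 cells (Homo sapiens) for inhibition, read by MTT assay, with a stated time of 48 h (a higher number here means a weaker inhibitor, a lower number a stronger inhibitor), compound 1 (`COc1ccc(CO[C@H]2C=C[C@H]3C/C=C\C[C@H](c4ccc(F)cc4)OC(=O)C[C@@H]2O3)cc1`) gives 8830 nM, and compound 2 (`COc1ccc(CO[C@H]2C=C[C@H]3C/C=C\C[C@H](c4ccc5ccccc5c4)OC(=O)C[C@@H]2O3)cc1`) gives 10200 nM. Among the measured compounds shown here, these two numbers lie within the scatter of each other, so neither compound can be ranked ahead, and compound 1 sits level with the only other measured compound.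

For the measured compounds named here, the next compound, compound 3 (`O=C1C[C@@H]2O[C@@H](C=C[C@@H]2O)C/C=C\C[C@H](c2ccc(F)cc2)O1`), has no measurement yet. It differs from compound 1 by one change, (hydrogen in place of 4-methoxybenzyl on an oxygen on a saturated carbon), which turns (4-methoxybenzyl)oxy into hydroxy.

Going by the values given here, only one measured step exists, a 1.2-fold higher number from compound 1 to compound 2 (0.06 log units; within the scatter). It is naphthalen-2-yl in place of 4-fluorophenyl on a saturated ring carbon, so it concerns a different place in the molecule. Among the compounds with values here, no measured pair tests the oxygen substituent, and the size of this step remains poorly constrained. A moderate move towards a higher number in this assay, meaning a weaker inhibitor, is expected, but with low confidence.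

The expected size of the change is a 2.3-fold higher number from compound 1 to compound 3 (0.36 log units; beyond the scatter). Compound 3 is estimated at 20000 nM, with an expected range of 6000 nM to 70000 nM.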

Compound 3, half-maximal inhibitory concentration: 40200 nM
Beside the measured number, compound 3's estimate is 2.0-fold (0.30 log units) below it; the range from low to high includes it.
By their numbers in this assay, from the lowest: compounds 1 and 2 (each within the scatter of the next); then compound 3.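

Among the compounds shown here, this is the first change at this oxygen, and in this assay the step from (4-methoxybenzyl)oxy to hydroxy gives a 4.6-fold higher number from compound 1 to compound 3 (0.66 log units; beyond the scatter). For the compounds shown here, it lies beyond the scatter, unlike the aryl swap at the other place in the molecule, a 1.2-fold higher number from compound 1 to compound 2 (0.06 log units; within the scatter), so the oxygen substituent is the first place in this short series where a single change clearly moves the number: the inhibitor with the 4-methoxybenzyl group is the stronger one, and the free hydroxy form is weaker. Nothing here shows why losing these nine heavy atoms, with their aromatic ring, weakens inhibition, as no supporting measurement bears on the cause.

The compounds shown leave open whether the step depends on the whole 4-methoxybenzyl group or on only part of it, since a plain benzyl or a small methyl on this oxygen would separate the aromatic ring and the methoxy from simple capping of the hydroxy. Going by these compounds, it also remains open whether the same step would appear with naphthalen-2-yl in place of 4-fluorophenyl, as this single pair carries 4-fluorophenyl only.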